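Replacing chloro with trifluoromethyl in compound 3

The source may report more compounds than this note shows. Statements on the series, on what has been measured and on what is new or still open speak of the compounds shown alone.

compound 1 `CC(C)c1cccc(NC(=O)Nc2cccc(-c3cccc4[nH]nc(N)c34)c2)c1`: 280 nM
compound 2 `Nc1n[nH]c2cccc(-c3cccc(NC(=O)Nc4nccs4)c3)c12`: 550 nM
compound 3 `Nc1n[nH]c2cccc(-c3cccc(NC(=O)Nc4cccc(Cl)c4)c3)c12`: 1830 nM

All three values come from a functional assay on SMMC-7721 cells (Homo sapiens) for inhibition, read by MTT assay, with a stated time of 48 h; a lower number here means a stronger inhibitor, a higher number a weaker inhibitor. Compound 3 is the weakest inhibitor of the three, shown by a 3.3-fold higher number from compound 2 to compound 3 (0.52 log units; beyond the scatter) and by a 6.5-fold higher number from compound 1 to compound 3 (0.82 log units; beyond the scatter). Compound 4 `Nc1n[nH]c2cccc(-c3cccc(NC(=O)Nc4cccc(C(F)(F)F)c4)c3)c12` has trifluoromethyl in place of chloro on an aromatic carbon, meta to a large group: trifluoromethyl in place of chloro on an aromatic carbon. The most relevant measured change is the replacement of isopropyl by chloro on an aromatic carbon, a 6.5-fold higher number from compound 1 to compound 3 (0.82 log units; beyond the scatter). This single swap is thin evidence, but it suggests that compound 3 may have room to improve when chloro is replaced. A modest move to a lower number in this assay is expected, an estimated 2.3-fold lower number from compound 3 to compound 4 (0.36 log units; beyond the scatter). For compound 4 the expected value is 800 nM, with an estimated range of 250 nM to 2500 nM.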

Compound 4, half-maximal inhibitory concentration: 1410 nM
For compound 4 the middle estimate is 1.8-fold (0.25 log units) below the measured one; the range from low to high includes it.
By their numbers in this assay, from the lowest: compounds 1 and 2 (each within the scatter of the next); then compounds 4 and 3 (each within the scatter of the next).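

Within this assay the swap of chloro for trifluoromethyl, with four heavy atoms entering for one, gives a 1.3-fold lower number from compound 3 to compound 4 (0.11 log units; within the scatter) and so does not separate these two groups on this aromatic carbon. Like compound 3, compound 4 sits on the higher side of the other two compounds, with a 2.6-fold higher number from compound 2 to compound 4 (0.41 log units; beyond the scatter) and a 5.0-fold higher number from compound 1 to compound 4 (0.70 log units; beyond the scatter) as its steps, both beyond the scatter. Nothing measured here explains this result. On these data alone, whether an amine, a carboxylic acid or a longer alkyl chain on this carbon would shift the number beyond the scatter remains open.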